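The source may report more compounds than this note shows. Statements on the series, on what has been measured and on what is new or still open speak of the compounds shown alone.

Measured so far:
Compound 1 `CCC(CC)N(CCN(C)C(=O)CCC(=O)O)Cc1cccc(C(=O)Nc2sc3c(c2C(=O)c2cnn(-c4ccc(Cl)cc4)c2)CCN(C(C)=O)C3)c1`: in an assay on isolated protein for inhibition of sodium-dependent phosphate transport protein 2B (Homo sapiens) (a higher number here means a weaker inhibitor, a lower number a stronger inhibitor), compound 1 gives > 1000 nM, a limit of the assay and not a number.
Compound 2 `CCC(CC)N(CCN(C)C(=O)CCC(=O)O)Cc1cccc(C(=O)Nc2sc3c(c2C(=O)c2cnn(-c4ccc(Cl)cc4)c2)CCN(S(C)(=O)=O)C3)c1`: in this assay compound 2 gives 2490 nM.

Going by the values given here, compound 2 therefore holds the only number in this set; the one other result is a limit. Among the compounds with values here, the single measured step, a step that the limit leaves unreadable from compound 1 to compound 2, cannot be read in size, as the limit of > 1000 nM in this assay, at which 1 of the 2 values shown sits, sits at one of its two ends, so it offers no scale for what a change on the ring amine nitrogen does here.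

Compound 3 `CCC(CC)N(CCN(C)C(=O)CCC(=O)O)Cc1cccc(C(=O)Nc2sc3c(c2C(=O)c2cnn(-c4ccc(Cl)cc4)c2)CCN(C2CC2)C3)c1` carries the change (cyclopropyl in place of methylsulfonyl on an amine nitrogen in a ring). Within the data shown here, no measured step bears on this change in a readable way, and so the only anchor for compound 3 is the value of compound 2 in this assay, 2490 nM. With no evidence pointing either way, the step from compound 2 is expected to stay within the scatter, so a 1.0-fold higher number from compound 2 to compound 3 (0.00 log units; within the scatter) is the estimated size. Compound 3 is thus expected to give about 2500 nM in this assay, within a range from 600 nM to 10000 nM, with a fair chance that only a limit is reported.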

Compound 3, half-maximal inhibitory concentration: 80 nM
For compound 3 the middle estimate is 31-fold (1.49 log units) above the measured one; measured number outside the range, below it.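

On the amine nitrogen in the ring, the choice of group proves to matter a great deal in this assay, a scale that the earlier pair could not give: replacing methylsulfonyl with cyclopropyl gives a 31-fold lower number from compound 2 to compound 3 (1.49 log units; beyond the scatter), with the rest of the molecule unchanged. Cyclopropyl also stands apart from acetyl, with an at least 12-fold lower number from compound 1 to compound 3 (1.09 log units; beyond the scatter), so among the three groups shown on this nitrogen, it alone gives a number in the range of compound 3, while methylsulfonyl and acetyl both leave the compounds much weaker. The result for compound 1 is a limit and not a number, so the step from it gives only a minimum size and does not show how acetyl and methylsulfonyl compare: the limit of > 1000 nM in this assay, at which 1 of the 3 values shown sits.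

Nothing measured here accounts for the size of the step to cyclopropyl. The compounds shown also leave open whether the gain belongs to the three-membered ring itself or would also appear with a plain alkyl group such as methyl or isopropyl, with a larger ring such as cyclobutyl, or with a hydrogen on this nitrogen.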